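A diethylamino swap among well-tolerated compounds

A few compounds are considered here, and "the series" means these few. Any claim that something is new, unique, unknown or untested is made for them only; others in the source may bear on it.

Each value below is a limit in a toxicity assay on MDCK cells (Canis lupus familiaris) for cytotoxicity, read by CCK-8 assay, with a stated time of 48 h; a higher number here means that more compound is tolerated, a lower number that less compound is tolerated

Compound 1 (`CCOc1ccc(C(=O)NNc2c(Br)cccc2Br)cc1`) gives the limit > 100000 nM
Compound 2 (`N#Cc1ccc(C(=O)NNc2c(Br)cccc2Br)cc1`) gives the limit > 100000 nM
Compound 3 (`O=C(NNc1c(Br)cccc1Br)c1ccc(F)cc1`) gives the limit > 100000 nM

Compound 3 stands only at the limit > 100000 nM and has no number. Compound 4 (`CCN(CC)c1ccc(C(=O)NNc2c(Br)cccc2Br)cc1`) carries diethylamino in place of fluoro on an aromatic carbon. Three measured steps at this place bear on the change, and none has a readable size (a step that the two limits leave unreadable from compound 1 to compound 2; a step that the two limits leave unreadable from compound 1 to compound 3; a step that the two limits leave unreadable from compound 2 to compound 3). Compound 1, compound 2 and compound 3 all share one ceiling (the limit of > 100000 nM in this assay, at which 3 of the 3 values shown sit). A step beyond the scatter is therefore not expected, in either direction, and the expected step is small (a number no higher from compound 3 to compound 4 (the limit leaves the size open)). For compound 4 the estimated value is 100000 nM with an expected range from 40000 nM to 200000 nM and a limit is the likely report.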

Compound 4, half-maximal cytotoxic concentration: 34000 nM
For compound 4 the middle estimate is 2.9-fold (0.47 log units) above the measured one, and the stated range ends above it.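

Putting diethylamino at this position in this assay gives an at least 2.9-fold lower number from compound 3 to compound 4 (0.46 log units; beyond the scatter) in place of fluoro, an at least 2.9-fold lower number from compound 2 to compound 4 (0.46 log units; beyond the scatter) in place of cyano and an at least 2.9-fold lower number from compound 1 to compound 4 (0.46 log units; beyond the scatter) in place of ethoxy. The steps among fluoro, cyano and ethoxy cannot be read, so this is the first sign that the group here can change how much compound is tolerated: the limit of > 100000 nM in this assay, at which 3 of the 4 values shown sit.

As far as these compounds go, each new step starts from a limit, so its full size stays open. The compounds shown also do not tell whether dimethylamino, or a longer chain on the nitrogen, would lower the number too.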